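A few compounds are considered here, and "the series" means these few. Any claim that something is new, unique, unknown or untested is made for them only; others in the source may bear on it.

Measured compounds:
Compound 1, `CN1C(=O)NC2(CC2(C)C)C1=O`, which in a functional assay on the whole organism for inhibition, with Mus musculus as the target, in the maximal electroshock model, at a dose of 15 mg/kg by the oral route (a lower number here means a weaker effect, a higher number a stronger effect of the compound at the dose given), gives 50%.
Compound 2, `CCCCN1C(=O)NC2(CC2(C)C)C1=O`, which in this assay gives 50%.

Compound 2 stands level with compound 1 on the numbers shown: the step of no change at the digits printed from compound 1 to compound 2 (within the scatter) shows that the change of hydrogen to propyl on the saturated chain carbon bound to the ring nitrogen left the read-out where it was. Only these two compounds were measured, so no further comparison is available.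

Compound 3, `CCC(CO)N1C(=O)NC2(CC2(C)C)C1=O`, has not yet been measured. It differs from compound 2 in one place: 1-(hydroxymethyl)propyl in place of butyl on an amide-type nitrogen in a ring.

Going by the values given here, the one measured step that bears on this change is the one from compound 1 to compound 2, which also altered the group on the same ring nitrogen and gave no change at the digits printed from compound 1 to compound 2 (within the scatter). Among the compounds with values here, nothing among the measured compounds speaks to a hydroxymethyl group on that chain, so the expectation for compound 3 rests on that single step alone and is held loosely. The step from compound 2 to compound 3 is therefore expected to be a number 3 percentage points lower from compound 2 to compound 3 (within the scatter), that is, nothing beyond the scatter in either direction. For compound 3 the estimated value in this assay is 47%, with a range from 20% to 75%.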

Compound 3, a percentage reported as inhibition, in the whole organism at one dose (the size of the read-out at that dose, not a potency): 50%
For compound 3 the middle estimate is 3 percentage points below the measured one; the measured number falls inside the stated range.
By their numbers in this assay, from the lowest: compounds 1, 2 and 3 (each within the scatter of the next).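

In this assay, putting 1-(hydroxymethyl)propyl in place of butyl on the amide-type nitrogen in the ring gives no change at the digits printed from compound 2 to compound 3 (within the scatter) and so extends what compound 2 showed: a chain carrying oxygen, with a hydrogen-bond donor and acceptor that butyl lacks, can stand at this position without the read-out moving beyond the scatter. The comparison with the smallest group shown gives no change at the digits printed from compound 1 to compound 3 (within the scatter) and places methyl, butyl and 1-(hydroxymethyl)propyl level with one another, whereas the earlier pair covered only plain carbon chains. This read-out is taken at one dose. The three compounds are level in the size of their effect at that dose, and nothing here goes beyond that dose.

From the compounds shown here alone, it remains open whether an amine, a carboxylic acid or a phenyl ring on this nitrogen would keep the read-out at the same level, and whether the level would hold at other doses. No measurement shown here accounts for the read-out staying level across these groups.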